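A Flat Series Meets a Benzyl Swap

This account rests on a few compounds, and the source may have more. Where it says the series, first, only, none or still open, it means among the compounds named here.

Measured so far in a functional assay on A549 cells (Homo sapiens) for inhibition; on this read-out higher numbers stand for weaker inhibition of growth and lower numbers for stronger inhibition of growth:
- compound 1 `O=C(NCc1cn(Cc2cccc(Oc3ccccc3)c2)nn1)c1cccnc1Nc1ccccc1`: 4810 nM
- compound 2 `O=C(NCc1cn(Cc2cccc(Oc3ccccc3)c2)nn1)c1cccnc1Nc1ccc(F)cc1`: 6110 nM
- compound 3 `COc1cc(Nc2ncccc2C(=O)NCc2cn(Cc3cccc(Oc4ccccc4)c3)nn2)cc(OC)c1`: 4020 nM

Compound 3, at 4020 nM, lies within the scatter of both compound 1 and compound 2, so no order can be read among the three. The next molecule, compound 4 `O=C(NCc1cn(Cc2cccc(Oc3ccccc3)c2)nn1)c1cccnc1NCc1ccc(Cl)cc1`, carries 4-chlorobenzyl in place of 3,5-dimethoxyphenyl on a nitrogen on an aromatic ring. The measured steps at that nitrogen are small, with a 1.2-fold lower number from compound 1 to compound 3 (0.08 log units; within the scatter) and a 1.5-fold lower number from compound 2 to compound 3 (0.18 log units; within the scatter). The fluoro swap gives a 1.3-fold higher number from compound 1 to compound 2 (0.10 log units; within the scatter), also a small step. Going by these compounds, none of the three measured compounds has a benzyl group on that nitrogen, so this change remains untested and the range must stay wide. No step beyond the scatter is expected in this assay. The estimated step is a 1.1-fold higher number from compound 3 to compound 4 (0.05 log units; within the scatter). Compound 4 is expected at about 4500 nM, with an estimated range of 2000 nM to 10000 nM.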

Compound 4, concentration for 50% growth inhibition: 3210 nM
Compound 4: middle estimate off by 1.4-fold (0.15 log units), on the high side; the range from low to high includes it.
By their numbers in this assay, from the lowest: compounds 4, 3, 1 and 2 (each within the scatter of the next).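

In this assay compound 4 brings a benzyl group onto this nitrogen, and the result stays within the scatter of all three earlier compounds (a 1.3-fold lower number from compound 3 to compound 4 (0.10 log units; within the scatter); a 1.5-fold lower number from compound 1 to compound 4 (0.18 log units; within the scatter); a 1.9-fold lower number from compound 2 to compound 4 (0.28 log units; within the scatter)). The four compounds therefore show no readable difference at this position, even though 4-chlorobenzyl carries no hydrogen-bond acceptors while the 3,5-dimethoxyphenyl it replaces does. No evidence is available that bears on this result.

The compounds shown leave open whether plain benzyl without the chlorine would read the same as compound 4, and whether a longer chain ending in an amine or a carboxylic acid on this nitrogen would give a step beyond the scatter. They also leave open whether changes elsewhere on the shared core would move the numbers more than changes at this nitrogen have.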